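Removing the Phenyl Ring: Effect on Paw-Edema Inhibition

The source may report more compounds than this note shows. Statements on the series, on what has been measured and on what is new or still open speak of the compounds shown alone.

Measured so far:
Compound 1 `Nc1nc(-c2ccccc2)c(C(=O)c2cnc3ccccn23)s1` gives 40% in a functional assay on the whole organism (strain Sprague-Dawley) for inhibition, with Rattus norvegicus as the target, read by paw edema, with stated times of 1 h and 3 h, at a dose of 50 mg/kg by the oral route; a lower number here means less inhibition, a higher number more inhibition at the dose given (going by the name of the read-out).
Compound 2 `Cc1ccn2c(C(=O)c3sc(N)nc3-c3ccccc3)cnc2c1` gives 26% in this assay.

Among the compounds with values here, compound 2 stands lowest of the two numbers; the single measured step, a number 14 percentage points lower from compound 1 to compound 2 (beyond the scatter), separates them. Compound 3 `Cc1ccn2c(C(=O)c3cnc(N)s3)cnc2c1` differs from compound 2 by hydrogen in place of phenyl on an aromatic carbon. Within the data shown here, no measured step concerns hydrogen in place of phenyl; the one step on record concerns methyl in place of hydrogen and does not bear on it. Compound 3 is therefore expected to give 18%, with a range from 0% to 38%. The estimated step of a number 8 percentage points lower from compound 2 to compound 3 (within the scatter) is expected to lean lower, though with wide uncertainty.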

Compound 3, a percentage reported as inhibition, in the whole organism at one dose (the size of the read-out at that dose, not a potency): 77%
For compound 3 the middle estimate is 59 percentage points below the measured one, and the stated range ends below it.
By their numbers in this assay, from the lowest: compound 2; then compound 1; then compound 3.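

Replacing phenyl with hydrogen on the aromatic carbon next to the ring nitrogen gives, in this assay, a number 51 percentage points higher from compound 2 to compound 3 (beyond the scatter). The phenyl is therefore not required at this position for inhibition at the dose given, and its loss is accompanied by a large gain, something the earlier methyl change could not show. Nothing available explains this gain.

From the compounds shown here alone, it remains open how a chlorine atom, an amine or an ethyl chain on this carbon would compare with hydrogen. Whether the methyl of compound 3 matters with hydrogen in this place is also unresolved.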